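Nitro in place of chloro: compound 2 to compound 4

The compounds below may be only part of what the source reports. "The series", "measured", "known", "first", "only" and "open" are said of these compounds alone.

Compound 1 `CSCC[C@H](NC(=O)c1ccc(NCc2cncn2Cc2cccc(C)c2)cc1-c1ccccc1)C(=O)O`: in a functional assay on NIH3T3 cells (Mus musculus) (a higher number here means that more compound is needed for the effect, a lower number that less compound is needed), compound 1 gives > 10 uM, a limit of the assay.
Compound 2 `COC(=O)[C@H](CCSC)NC(=O)c1ccc(NCc2cncn2Cc2ccc(Cl)cc2)cc1-c1ccccc1`: in this assay compound 2 gives > 10 uM, a limit.
Compound 3 `CSCC[C@H](NC(=O)c1ccc(NCc2cncn2Cc2ccc(C)cc2)cc1-c1ccccc1)C(=O)O`: in this assay compound 3 gives > 10 uM, a limit.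

Compound 2 stands at the limit of > 10 uM in this assay, at which 3 of the 3 values shown sit. Within the data shown here, the only step between measured compounds, a step that the two limits leave unreadable from compound 1 to compound 3, cannot be read from two limits. Compound 4 `COC(=O)[C@H](CCSC)NC(=O)c1ccc(NCc2cncn2Cc2ccc([N+](=O)[O-])cc2)cc1-c1ccccc1` differs from compound 2 by nitro in place of chloro on an aromatic carbon. Among the measured compounds shown here, no measured step bears on nitro in place of chloro, and every value in this assay is a limit, so the series gives no direction. Compound 4 is therefore expected to stay near the limit, with the step from compound 2 estimated as a step that the limit leaves unreadable from compound 2 to compound 4. The estimate for compound 4 is 20 uM, ranging from 5 uM to 100 uM, most likely reported as a limit again.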

Compound 4, concentration for half-maximal effect: > 10 uM
Compound 4 ended at the assay's limit (the forecaster's own chance of this, stated with the estimate: 80%); the middle value lies beyond the limit too.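

No step can be read between compound 2 and compound 4, as both stand at a limit: the limit of > 10 uM in this assay, at which 4 of the 4 values shown sit.

The compounds shown leave open how far each lies beyond that limit, and whether nitro in place of chloro changes anything in this assay.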